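A few compounds are considered here, and "the series" means these few. Any claim that something is new, unique, unknown or untested is made for them only; others in the source may bear on it.

Series values in a functional assay on A-375 cells (Homo sapiens) for inhibition, read by sulforhodamine B assay, with a stated time of 6 days; a lower number here means a stronger inhibitor, a higher number a weaker inhibitor:
- compound 1 `CNCCNCc1cccc(-c2nc(Nc3ccccc3)c(C)c(-c3c(C)nn(C)c3C)n2)c1`: 6700 nM
- compound 2 `CNCCNCc1cccc(-c2nc(NC3CCOCC3)c(C)c(-c3c(C)nn(C)c3C)n2)c1`: > 50000 nM (a limit of the assay, not a number)
- compound 3 `CNCCNCc1cccc(-c2nc(NC3CCOCC3)c(C)c(-c3ccncc3)n2)c1`: 44300 nM

Compound 1 holds the lowest number shown, and it is the only one of the three with an anilino group. At 6700 nM, compound 1 lies clearly under compound 3 at 44300 nM.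

Compound 4 `CNCCNCc1cccc(-c2nc(Nc3ccccc3)c(C)c(-c3cccnc3)n2)c1` keeps the anilino group of compound 1 and changes one substituent of the core: pyridin-3-yl in place of 1,3,5-trimethyl-1H-pyrazol-4-yl on an aromatic carbon. Pyridin-3-yl takes the place of 1,3,5-trimethyl-1H-pyrazol-4-yl on an aromatic carbon.

Among the compounds with values here, two measured steps bear on this. The larger, an at least 7.4-fold higher number from compound 1 to compound 2 (0.87 log units; beyond the scatter), is a change at the other place, oxan-4-yl in place of phenyl, which compound 4 does not make. The closer one, an at least 1.1-fold lower number from compound 2 to compound 3 (0.05 log units; that floor lies within the scatter), brings in pyridin-4-yl rather than pyridin-3-yl, starts from a limit, and has a floor within the scatter. It therefore gives no sign of a real shift, though it is only a weak guide to a step on the anilino side.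

Going by these compounds, no step beyond the scatter is expected in this assay, and the direction stays open. The estimated change is a 1.1-fold lower number from compound 1 to compound 4 (0.05 log units; within the scatter). For compound 4 the expected value is 6000 nM, with an expected range of 2000 nM to 20000 nM.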

Compound 4, half-maximal inhibitory concentration: 10900 nM
For compound 4 the middle estimate is 1.8-fold (0.26 log units) below the measured one; measured number inside the range.
By their numbers in this assay, from the lowest: compounds 1 and 4 (each within the scatter of the next); then compound 3. At a limit, above all of these: compound 2.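

In this assay, the replacement on the aromatic carbon ortho to the methyl group, with the anilino group kept, reads as a 1.6-fold higher number from compound 1 to compound 4 (0.21 log units; within the scatter). Both ends of this step are numbers, so with the anilino group in place, pyridin-3-yl and 1,3,5-trimethyl-1H-pyrazol-4-yl show no difference beyond the scatter at this position, although one is a six-membered and the other a five-membered aromatic ring. The earlier step at this position, on the oxan-4-yl side, gave only a floor, because compound 2 stands at a limit and not at a number: the limit of > 50000 nM in this assay, at which 1 of the 4 values shown sits.

Whether this position accepts a ring without a hetero atom, such as plain phenyl, or a non-aromatic group, such as piperidin-4-yl or morpholine, stays open, as the compounds shown carry only aromatic heterocycles there. Compound 3 and compound 4 differ in two places, so pyridin-4-yl and pyridin-3-yl cannot be set against each other, and the position of the ring nitrogen in the pyridine remains unresolved in this series.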